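Removing a Chlorine From a Weakly Active Scaffold

The source may hold more compounds than are shown below. What is called first, only, known or untested is meant among the compounds shown, and "the series" means these compounds.

Of the compounds shown here, three that share one core have been tested in a functional assay on HeLa cells (Homo sapiens) for cytotoxicity, read by MTT assay, with a stated time of 24 h; a higher number here means a weaker inhibitor, a lower number a stronger inhibitor. Compound 1 `Cc1cc(O)c(C(=O)/C=C/c2cccc3ccccc23)c(-c2ccc(Cl)cc2)c1C(=O)/C=C/c1cccc2ccccc12` gives "not active" (no number reported), so no number stands for it. Within the data shown here, compound 2 `Cc1cc(O)c(C(=O)/C=C/c2ccc(Br)cc2)c(-c2ccccc2)c1C(=O)/C=C/c1ccc(Br)cc1` gives 33500 nM in this assay, a weak effect and the only number in the set. Compound 3 `Cc1cc(O)c(C(=O)/C=C/c2ccc3ccccc3c2)c(-c2ccc(Cl)cc2)c1C(=O)/C=C/c1ccc2ccccc2c1` gives "not active" (no number reported) in this assay; it therefore stands, like compound 1, without a number, and its result can only be placed as weaker than, or not distinguishable from, what the assay can report.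

Compound 4 `Cc1cc(O)c(C(=O)/C=C/c2ccc3ccccc3c2)c(-c2ccccc2)c1C(=O)/C=C/c1ccc2ccccc2c1` has not yet been measured. It differs from compound 3 in a single place: hydrogen in place of chloro on an aromatic carbon. Among the measured compounds shown here, no pair among the measured compounds shows what this change does on its own; compound 2 also carries a plain phenyl, but it differs from compound 4 in its arms as well, so the two cannot be read as a step. With compound 3 giving no number, the expectation for compound 4 in this assay is a step of no clear size and no clear direction, most likely none beyond the usual scatter, with a fair chance that again only a limit is reported. Compound 4 is expected to give about 60000 nM, with a plausible range from 20000 nM to 200000 nM.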

Compound 4, half-maximal inhibitory concentration: "not active" (no number reported)
Compound 4: no number reported; there is nothing to compare the estimate with.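

In this assay compound 3 gives "not active" (no number reported) and compound 4 gives "not active" (no number reported) so no step can be read between these two compounds. Nothing available here explains this result. Going by these compounds, what the change from 4-chlorophenyl to phenyl does on its own in this assay stays open, in size and in direction.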